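A few compounds are considered here, and "the series" means these few. Any claim that something is new, unique, unknown or untested is made for them only; others in the source may bear on it.

Compound 3 `CN(C(=O)NC(=O)c1c(F)cccc1F)c1nc(C(F)(F)F)c(C(=O)N/N=C/c2ccc(C(F)(F)F)cc2)s1` belongs to a small set built on a shared core carrying an acyl hydrazone and an acylurea. For the measured compounds named here, in a functional assay on MCF7 cells (Homo sapiens) for inhibition, read by MTT assay, with a stated time of 72 h (on this read-out lower numbers stand for stronger inhibition and higher numbers for weaker inhibition), compound 3 gives 35.3 ug/mL, the highest number of the three measured members. Compound 2 `CN(C(=O)NC(=O)c1ccccc1F)c1nc(C(F)(F)F)c(C(=O)N/N=C/c2ccccc2C(F)(F)F)s1` gives 12.2 ug/mL, and compound 1 `CN(C(=O)NC(=O)c1ccc(Cl)cc1Cl)c1nc(C(F)(F)F)c(C(=O)N/N=C/c2ccc(C(F)(F)F)cc2)s1` gives 8.42 ug/mL. Going by the values given here, the one step that can be traced in this set is a 4.2-fold higher number from compound 1 to compound 3 (0.62 log units; beyond the scatter). Compound 4 `CN(C(=O)NC(=O)c1ccccc1F)c1nc(C(F)(F)F)c(C(=O)N/N=C/c2ccc(C(F)(F)F)cc2)s1` differs from compound 3 in that (hydrogen in place of fluoro on an aromatic carbon). Among the compounds with values here, no measured pair isolates the removal of a single fluoro, but compound 2 already carries the 2-fluorophenyl group on the same carbonyl, and its number stands beyond the scatter below that of compound 3; compound 1, with a different aryl at the same position, stands lower still. Given that compound 3 sits at the top of the range, compound 4 is therefore expected to move to a lower number, a step of a 2.7-fold lower number from compound 3 to compound 4 (0.43 log units; beyond the scatter). Compound 4 is estimated at 13 ug/mL, within 5 ug/mL to 32 ug/mL.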

Compound 4, half-maximal inhibitory concentration: 4.98 ug/mL
Compound 4: the middle estimate sits 2.6-fold (0.42 log units) above what was measured; measured number outside the range, below it.
By their numbers in this assay, from the lowest: compounds 4, 1 and 2 (each within the scatter of the next, the first and the last beyond it); then compound 3.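

In this assay, for the compounds shown here, hydrogen in place of fluoro on the aromatic carbon, which turns 2,6-difluorophenyl into 2-fluorophenyl, gives a 7.1-fold lower number from compound 3 to compound 4 (0.85 log units; beyond the scatter); this is the first measured view of that single change. With the 2-fluorophenyl group held constant, 4-(trifluoromethyl)phenyl in place of 2-(trifluoromethyl)phenyl gives a 2.4-fold lower number from compound 2 to compound 4 (0.39 log units; beyond the scatter), so the number also responds to where the trifluoromethyl group sits on the other aryl group. The 2-fluorophenyl and 2,4-dichlorophenyl groups, by contrast, are not separated in this assay, with a 1.7-fold lower number from compound 1 to compound 4 (0.23 log units; within the scatter).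

Nothing measured here bears on what lies behind these shifts. Going by these compounds, it remains open whether a plain phenyl group, or a methoxy or amino group in place of the remaining fluoro, would keep the number as low.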